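Methyl in place of chloro: notes on compound 3

The source may report more compounds than this note shows. Statements on the series, on what has been measured and on what is new or still open speak of the compounds shown alone.

In a functional assay on HeLa cells (Homo sapiens) for inhibition, read by CCK-8 assay, with a stated time of 72 h, tested at 8 uM (on this read-out higher numbers stand for more inhibition of growth at the one concentration tested and lower numbers for less inhibition of growth), compound 1 (`Nc1ccccc1NC(=O)/C=C/c1ccc(CSc2ccc(Cl)cc2)cc1`) gives 17.3%. Compound 2 (`COc1ccc(SCc2ccc(C(=O)Nc3ccccc3N)cc2)cc1`) gives 79.7%. Compound 1 is the lower of the two, and the gap between them lies beyond the scatter. Compound 3 (`Cc1ccc(SCc2ccc(/C=C/C(=O)Nc3ccccc3N)cc2)cc1`) keeps the core of compound 1 and carries methyl in place of chloro on an aromatic carbon, para to a large group: methyl in place of chloro on an aromatic carbon. Among the compounds with values here, no measured pair isolates this change, so the size of the step remains open. The expected a number 4.7 percentage points higher from compound 1 to compound 3 (within the scatter) is a slight rise, not beyond the scatter. For compound 3 the estimate is 22%, with an expected range of 7% to 45%.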

Compound 3, percent growth inhibition at one concentration: 21.7%
The estimate for compound 3 lay 0.3 percentage points above the measured number, within the range that was stated.
By their numbers in this assay, from the lowest: compounds 1 and 3 (each within the scatter of the next); then compound 2.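

In this assay, within the data shown here, methyl in place of chloro gives a number 4.4 percentage points higher from compound 1 to compound 3 (within the scatter), the first direct reading of this change at this position. With this core, the 4-chlorophenyl and 4-methylphenyl forms are therefore not told apart by this read-out. Nothing at hand bears on why the two groups read alike.

As far as these compounds go, whether an amine or a carboxylic acid on this aromatic carbon would move the number remains open. So does the effect of methyl in place of chloro on the core of compound 2.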